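Swapping a Hydroxyphenyl for a Fused Bicyclic Heteroaryl

The source may hold more compounds than are shown below. What is called first, only, known or untested is meant among the compounds shown, and "the series" means these compounds.

Of the compounds shown here, three built on one shared core have been tested in a functional assay on JAR cells (Homo sapiens) for inhibition, read by MTT assay, with a stated time of 72 h; a higher number here means a weaker inhibitor, a lower number a stronger inhibitor. Compound 1 `CCOC(=O)C1=C(Nc2ccccc2)S/C(=C\c2ccc([N+](=O)[O-])c(O)c2)C1=O` gives 12700 nM. Compound 2 `CCOC(=O)C1=C(Nc2ccccc2)S/C(=C\c2ccccc2O)C1=O` gives 8000 nM. Compound 3 `CCOC(=O)C1=C(Nc2ccccc2Br)S/C(=C\c2ccc[nH]2)C1=O` gives 8900 nM. Compound 2 has the lowest of these three numbers, but its nearest neighbour, compound 3, and its furthest, compound 1, both sit within the usual scatter of it, so the three cannot be separated on this evidence.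

Compound 4 `CCOC(=O)C1=C(Nc2ccccc2)S/C(=C\c2cc3ncccc3[nH]2)C1=O` has not yet been tested in this assay. It differs from compound 2 in one place: a group of 9 heavy atoms (7 carbon, 2 nitrogen; one five-membered aromatic ring with 1 hetero atom, one six-membered aromatic ring with 1 hetero atom) in place of a group of 7 heavy atoms (6 carbon, 1 oxygen; one six-membered aromatic ring of carbon only), on a double-bonded chain carbon bound to a double-bonded ring carbon. No measured pair among these compounds shows this change or anything like it, so its effect cannot be read off from the numbers at hand. Because compound 1 gives 12700 nM and compound 3 gives 8900 nM while compound 2 gives 8000 nM even though the three carry different aromatic groups at this same position, all within the scatter of one another, the working expectation is that compound 4 will stay close to compound 2, with no step beyond the scatter in either direction. The estimated step is a 1.1-fold lower number from compound 2 to compound 4 (0.06 log units; within the scatter). Compound 4 is therefore expected to give about 7000 nM in this assay, most likely between 2500 nM and 20000 nM.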

Compound 4, half-maximal inhibitory concentration: 9600 nM
Beside the measured number, compound 4's estimate is 1.4-fold (0.14 log units) below it; low and high end bracket the measured number.
By their numbers in this assay, from the lowest: compounds 2, 3, 4 and 1 (each within the scatter of the next).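

In this assay, going by these compounds alone, the first pair that can be compared directly at this position, on a double-bonded chain carbon bound to a double-bonded ring carbon, gives a 1.2-fold higher number from compound 2 to compound 4 (0.08 log units; within the scatter). Within the data shown here, the earlier compounds carried different groups here, but none of them differed from another in this one place alone, so this pair is the first clean reading: a 2-hydroxyphenyl of 7 heavy atoms with one carbon-only ring can be exchanged for a group of 9 heavy atoms with two aromatic rings, each holding a hetero atom, without a step beyond the scatter, even though the oxygen is lost and two nitrogens enter while the counted hydrogen-bond donor and acceptor stay the same. Nothing available explains this outcome or ties it to any particular feature of either group.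

This is a single pair, so it does not show how far such exchanges can go at this position. From the compounds shown here alone, whether a group of another kind here, such as a carboxylic acid or an amine on a longer chain, would give a step beyond the scatter remains open.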